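The source may report more compounds than this note shows. Statements on the series, on what has been measured and on what is new or still open speak of the compounds shown alone.

- compound 1 `O=C1NC(=O)c2c1c1c3ccc(C(F)(F)F)cc3[nH]c1c1c2c2cccc3c2n1CCC3`: 1480 nM
- compound 2 `O=C1NC(=O)c2c1c1c3ccc(CN4CCC4)cc3[nH]c1c1c2c2cccc3c2n1CCC3`: 230 nM
- compound 3 `O=C1NC(=O)c2c1c1c3ccc(CN4CCCCC4)cc3[nH]c1c1c2c2cccc3c2n1CCC3`: not yet measured

In a functional assay on HCT-116 cells (Homo sapiens) for cytotoxicity (a higher number here means a weaker inhibitor, a lower number a stronger inhibitor), compound 2 has the lower of the two measured numbers, 230 nM, which makes it the stronger inhibitor of the pair. Compound 3 keeps the shared core and changes only the ring attached to a saturated chain carbon bound to an aromatic carbon: piperidin-1-yl in place of azetidin-1-yl on a saturated chain carbon bound to an aromatic carbon. In words, piperidin-1-yl takes the place of azetidin-1-yl.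

Among the measured compounds shown here, only one measured step is available, and it bears on this change indirectly. It is a 6.4-fold lower number from compound 1 to compound 2 (0.81 log units; beyond the scatter), a modest step beyond the scatter, in which (azetidin-1-yl)methyl replaced trifluoromethyl on an aromatic carbon. The new change is narrower, since (azetidin-1-yl)methyl becomes (piperidin-1-yl)methyl. For the measured compounds named here, no measured pair shows what a change from a four-membered to a six-membered ring does here, so the data give no direction. A step beyond the scatter is therefore not expected, and the expected step is a 1.1-fold higher number from compound 2 to compound 3 (0.05 log units; within the scatter). For compound 3 the estimated value is 260 nM, with an expected range from 100 nM to 680 nM.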

Compound 3, half-maximal inhibitory concentration: 320 nM
Compound 3: the middle estimate sits 1.2-fold (0.09 log units) below what was measured; low and high end bracket the measured number.
By their numbers in this assay, from the lowest: compounds 2 and 3 (each within the scatter of the next); then compound 1.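

In this assay, piperidin-1-yl in place of azetidin-1-yl on a saturated chain carbon bound to an aromatic carbon gives a 1.4-fold higher number from compound 2 to compound 3 (0.14 log units; within the scatter), so this comparison does not separate the six-membered ring from the four-membered ring. The step from trifluoromethyl is now seen with a second ring, as a 4.6-fold lower number from compound 1 to compound 3 (0.67 log units; beyond the scatter), which means that the earlier step beyond the scatter is no longer tied to azetidin-1-yl alone: both (azetidin-1-yl)methyl and (piperidin-1-yl)methyl give lower numbers than trifluoromethyl on this aromatic carbon. No measurement shown here offers an explanation for either step.

The compounds shown leave open whether the ring nitrogen matters, and a direct test would be to compare cyclohexylmethyl, which has no nitrogen, or (morpholin-4-yl)methyl, which adds a ring oxygen, with the two rings above. They also leave open whether a ring is needed at all, which (dimethylamino)methyl could address, and whether a longer chain between the aromatic carbon and the piperidin-1-yl ring would keep the number in the same range.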